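A few compounds are considered here, and "the series" means these few. Any claim that something is new, unique, unknown or untested is made for them only; others in the source may bear on it.

- Compound 1 `CCCN(CC1CCOC1)C(=O)c1cc(OC)c2oc(NCc3cccc(Cl)c3)nc2c1`: 65 mL/min/kg
- Compound 2 `CCC1CC(O)C(C)CN1C(=O)c1cc(OC)c2oc(NCc3cccc(Cl)c3)nc2c1`: 61.7 mL/min/kg

In an ADME assay on cells (Hepatocyte, Rattus norvegicus, strain Wistar) for pharmacokinetics, read by LC-MS, with a stated time of 90 min, tested at 1 uM (on this read-out higher numbers stand for fast clearance and lower numbers for slow clearance), compound 2 gives 61.7 mL/min/kg and compound 1 gives 65 mL/min/kg. The two numbers lie within the usual scatter of each other, so the two compounds cannot be told apart on this read-out. Among the measured compounds shown here, the one measured step, a 1.1-fold lower number from compound 1 to compound 2 (0.02 log units; within the scatter), is also within the scatter. It exchanges the whole group on the carbonyl carbon, even though that exchange brings in a different amine group, so it bears only loosely on the next change.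

Compound 3 `COc1cc(C(=O)N2CC(C)C(O)CC2CCO)cc2nc(NCc3cccc(Cl)c3)oc12` follows from compound 2 by one small edit: hydroxy in place of hydrogen on a saturated chain carbon, two bonds along the chain from a saturated ring carbon. This turns ethyl to 2-hydroxyethyl. For the measured compounds named here, no measured pair shows what this edit does, so the size of the step cannot be read from the data. The expectation therefore stays close to compound 2, with a slight lean to a lower number and probably nothing beyond the scatter. The expected step is a 1.2-fold lower number from compound 2 to compound 3 (0.09 log units; within the scatter). For compound 3 the estimated clearance is 50 mL/min/kg, with an expected range from 30 mL/min/kg to 72 mL/min/kg.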

Compound 3, clearance: 4.5 mL/min/kg
Compound 3: middle estimate off by 11-fold (1.05 log units), on the high side, and the stated range ends above it.
By their numbers in this assay, from the lowest: compound 3; then compounds 2 and 1 (each within the scatter of the next).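

this assay now separates the compounds: ethyl to 2-hydroxyethyl, the addition of a single hydroxy on a saturated chain carbon, two bonds along the chain from a saturated ring carbon, gives a 14-fold lower number from compound 2 to compound 3 (1.14 log units; beyond the scatter). The earlier exchange of the whole group on the carbonyl carbon gave only a 1.1-fold lower number from compound 1 to compound 2 (0.02 log units; within the scatter), while the exchange that brings in 4-hydroxy-2-(2-hydroxyethyl)-5-methylpiperidin-1-yl gives a 14-fold lower number from compound 1 to compound 3 (1.16 log units; beyond the scatter), so among these three compounds the large difference appears only with the 2-hydroxyethyl group, and this chain position proves far more sensitive than the first pair suggested. Nothing available here accounts for the size of this step.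

The compounds shown leave open whether the step is specific to the hydroxy, or whether a methoxy, an amine or a carboxylic acid at the same place on the chain, or a longer chain ending in hydroxy, would give a similar number. They also leave open whether 2-hydroxyethyl would have the same effect on a piperidine lacking the 4-hydroxy or 5-methyl group, or on a different amine group on the carbonyl carbon.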